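This account rests on a few compounds, and the source may have more. Where it says the series, first, only, none or still open, it means among the compounds named here.

Three compounds have so far been measured in a functional assay on CHO cells for antagonist activity at growth hormone secretagogue receptor type 1 (Homo sapiens); on this read-out higher numbers stand for weaker inhibition and lower numbers for stronger inhibition:

Compound 1 `CCc1ccc(Cn2c(CCc3ccccc3)nnc2[C@H](NC(=O)c2ccccn2)c2c[nH]c3ccccc23)cc1` gives 513 nM.
Compound 2 `CCc1ccc(-n2c(CCc3c[nH]c4ccccc34)nnc2[C@H](NC(=O)c2ccccn2)c2c[nH]c3ccccc23)cc1` gives 129 nM.
Compound 3 `CCc1ccc(Cn2c(CCc3ccccc3)nnc2[C@H](NC(=O)Cc2ccccn2)c2c[nH]c3ccccc23)cc1` gives 124 nM.

Compound 1 and compound 3 share one core and differ in a single place: (pyridin-2-yl)methyl in place of pyridin-2-yl on a carbonyl carbon. That change gave a 4.1-fold lower number from compound 1 to compound 3 (0.62 log units; beyond the scatter), a clear gain in potency on this assay. Compound 2 is built on a different core; how its core differs from that of compound 1 is not broken down here. In this assay compound 2 and compound 3 give numbers that sit within the usual scatter of each other, so no order can be drawn between them.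

Compound 4 `CCc1ccc(-n2c(CCc3c[nH]c4ccccc34)nnc2[C@H](NC(=O)Cc2ccccn2)c2c[nH]c3ccccc23)cc1` is compound 2 with the same change applied: (pyridin-2-yl)methyl in place of pyridin-2-yl on a carbonyl carbon. The place of the change, a carbonyl carbon whose other neighbour is an amide-type nitrogen, is identical in both pairs, so this is the same change, now on the core of compound 2.

Going by the values given here, only one measured example of this change exists, and it sits on a different core, so how far it carries over is uncertain. A step of roughly the same kind as a 4.1-fold lower number from compound 1 to compound 3 (0.62 log units; beyond the scatter) is expected for compound 4, giving an estimated 3.2-fold lower number from compound 2 to compound 4 (0.51 log units; beyond the scatter), because compound 1 to compound 3 showed a 4.1-fold lower number from compound 1 to compound 3 (0.62 log units; beyond the scatter). Compound 4 is therefore estimated at 40 nM, with a likely range from 15 nM to 120 nM.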

Compound 4, antagonist equilibrium constant: 34 nM
Estimate against measurement, compound 4: 1.2-fold (0.07 log units) above; low and high end bracket the measured number.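

In this assay, putting (pyridin-2-yl)methyl in place of pyridin-2-yl on the carbonyl carbon gave a 3.8-fold lower number from compound 2 to compound 4 (0.58 log units; beyond the scatter), a clear gain in potency on the core of compound 2. The size of this gain matches that of the earlier step, so in this series the change carried from one core to the other with its effect intact: the same change on two cores in this assay, a 4.1-fold lower number (0.62 log units; beyond the scatter) from compound 1 to compound 3 and a 3.8-fold lower number (0.58 log units; beyond the scatter) from compound 2 to compound 4, 1.1-fold (0.04 log units) apart, within the scatter of two such steps

Going by these compounds alone, this rests on only two pairs of compounds in a single assay, so it shows that the step held on these two cores, but not that it would hold on any other core, and it does not explain why the added carbon gives stronger inhibition.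

The compounds shown leave open whether a longer chain on the same carbonyl carbon, such as (pyridin-2-yl)ethyl, would strengthen inhibition further or weaken it. They also leave open whether the ring nitrogen matters, which a phenylmethyl group in the same place could test by keeping the added carbon while removing that nitrogen.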